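From 3,4-difluorophenyl to 4-chlorophenyl on compound 3

The source may hold more compounds than are shown below. What is called first, only, known or untested is meant among the compounds shown, and "the series" means these compounds.

In a functional assay on A549 cells (Homo sapiens) for cytotoxicity, read by MTT assay, with a stated time of 48 h (a lower number here means a stronger inhibitor, a higher number a weaker inhibitor), compound 1 (`COc1ccc(/C=C/c2cc(OC)c(OC)c(OC)c2-c2ccc(F)c(F)c2)cc1`) gives 7500 nM, compound 2 (`COc1cc(/C=C/c2ccc(C)cc2)c(-c2ccccc2)c(OC)c1OC`) gives 54000 nM and compound 3 (`C=C(c1ccc(OC)cc1)c1cc(OC)c(OC)c(OC)c1-c1ccc(F)c(F)c1`) gives 6500 nM. Compound 3 therefore sits level with compound 1 and well under compound 2. Compound 4 (`C=C(c1ccc(OC)cc1)c1cc(OC)c(OC)c(OC)c1-c1ccc(Cl)cc1`) carries 4-chlorophenyl in place of 3,4-difluorophenyl on an aromatic carbon. Among the compounds with values here, the only measured step, a 1.2-fold lower number from compound 1 to compound 3 (0.06 log units; within the scatter), lies within the scatter, but it concerns the ethenyl group and not this position. Compound 2 differs from compound 3 in more than one place, so its gap does not isolate this change. Within the data shown here, no measured step changes this group alone, so no shift beyond the scatter is expected. The expected step is a 1.2-fold higher number from compound 3 to compound 4 (0.09 log units; within the scatter). For compound 4 the estimated value is 8000 nM, with an expected range of 3000 nM to 22000 nM.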

Compound 4, half-maximal inhibitory concentration: 29000 nM
Estimate against measurement, compound 4: 3.6-fold (0.56 log units) below, outside the stated range (above it).
By their numbers in this assay, from the lowest: compounds 3 and 1 (each within the scatter of the next); then compounds 4 and 2 (each within the scatter of the next).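

In this assay, within the data shown here, this aryl position responds to substitution: a 4.5-fold higher number from compound 3 to compound 4 (0.65 log units; beyond the scatter), beyond the scatter, whereas the one earlier step, at the ethenyl group, stayed within it. For this single pair, 3,4-difluorophenyl gives the lower number and 4-chlorophenyl the higher. No measurement shown accounts for the shift.

The compounds shown do not separate the effect of the chlorine entering from that of the fluorines leaving. On these data alone, how a phenyl ring carrying an amine or a carboxylic acid would read at this position also remains open.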